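A few compounds are considered here, and "the series" means these few. Any claim that something is new, unique, unknown or untested is made for them only; others in the source may bear on it.

Measured so far:
compound 1, `Brc1ccc2ncnc(Nc3ccccc3)c2c1` — > 10000 nM
compound 2, `Brc1cccc(Nc2ncnc3ccc(Br)cc23)c1` — 174 nM
compound 3, `COc1cccc(Nc2ncnc3ccc(Br)cc23)c1` — > 10000 nM

In a functional assay on HEK293 cells for antagonist activity at metabotropic glutamate receptor 5 (Rattus norvegicus), read by calcium flux (on this read-out lower numbers stand for stronger inhibition and higher numbers for weaker inhibition), compound 1 gives only a limit, > 10000 nM, and no number. Compound 3 likewise gives only a limit in this assay, > 10000 nM. Within the data shown here, compound 2 is the one compound with a measured number in this assay, 174 nM. Compound 1 thus stands at the limit of > 10000 nM in this assay, at which 2 of the 3 values shown sit, the weaker end of what has been seen.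

Compound 4, `Fc1ccc2ncnc(Nc3ccccc3)c2c1`, has not yet been measured. It differs from compound 1 in one place: fluoro in place of bromo on an aromatic carbon.

The measured steps touch a different part of the molecule. The step of an at least 57-fold lower number from compound 1 to compound 2 (1.75 log units; beyond the scatter) adds a bromo on the ring attached through the amine, and an at least 57-fold higher number from compound 2 to compound 3 (1.75 log units; beyond the scatter) exchanges that same bromo for methoxy; the step that the two limits leave unreadable from compound 1 to compound 3 stays between two limits. Among the measured compounds shown here, none of them alters the bromo on the core, so no measured step speaks directly to the change from compound 1 to compound 4. Compound 4 is therefore expected to remain near the limit where compound 1 sits, with a step that the limit leaves unreadable from compound 1 to compound 4 expected, none beyond the scatter. The estimate for compound 4 in this assay is 15000 nM, with a range from 4000 nM to 50000 nM.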

Compound 4, half-maximal inhibitory concentration: > 10000 nM
Compound 4: a limit, no number (the forecaster's own chance of this, stated with the estimate: 75%); the middle value lies beyond the limit too.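

In this assay compound 4 gives only a limit, as compound 1 does, so no step can be read between compound 1 and compound 4. The compounds shown leave open whether fluoro in place of bromo on the core changes inhibition at all, as both compounds rest at the same limit: the limit of > 10000 nM in this assay, at which 3 of the 4 values shown sit.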